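Benzyl amide series: moving the methyl on the aryl ring

This account rests on a few compounds, and the source may have more. Where it says the series, first, only, none or still open, it means among the compounds named here.

Measured so far:
- compound 1 `Cc1ccc(CN(C)C(=O)c2nn(-c3ccc(F)cc3)c(OC[C@@H](O)C[C@@H](O)CC(=O)O)c2C(C)C)cc1`: 37 nM
- compound 2 `CC(C)c1c(C(=O)N2CCC[C@H](c3ccccc3)C2)nn(-c2ccc(F)cc2)c1OC[C@@H](O)C[C@@H](O)CC(=O)O`: 4.8 nM
- compound 3 `COc1cc(CN(C)C(=O)c2nn(-c3ccc(F)cc3)c(OC[C@@H](O)C[C@@H](O)CC(=O)O)c2C(C)C)cc(OC)c1`: 43 nM

All three share one core and are read in an assay on microsomes from liver for inhibition of 3-hydroxy-3-methylglutaryl-coenzyme A reductase (Rattus norvegicus); a lower number here means a stronger inhibitor, a higher number a weaker inhibitor. Within the data shown here, compound 1 stands second highest of the three numbers; its nearest neighbour is compound 3 (a 1.2-fold higher number from compound 1 to compound 3 (0.07 log units; within the scatter)), and the only step beyond the scatter is to compound 2 (a 7.7-fold lower number from compound 1 to compound 2 (0.89 log units; beyond the scatter)).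

Compound 4 `Cc1cccc(CN(C)C(=O)c2nn(-c3ccc(F)cc3)c(OC[C@@H](O)C[C@@H](O)CC(=O)O)c2C(C)C)c1` is not yet measured. It differs from compound 1 by 3-methylphenyl in place of 4-methylphenyl on a saturated chain carbon bound to an amide-type nitrogen.

Of the two steps from compound 1, the one that bears on this change is the step to compound 3, where the aryl ring on the same saturated chain carbon bound to the amide-type nitrogen was exchanged and the number stayed within the scatter. The step to compound 2 replaces the whole amine part and says little here. A small change in the methyl position on that aryl ring is therefore expected to give no step beyond the scatter in this assay; the expected step is a 1.1-fold higher number from compound 1 to compound 4 (0.03 log units; within the scatter). Compound 4 is estimated at 40 nM, within 18 nM to 90 nM.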

Compound 4, half-maximal inhibitory concentration: 37 nM
Estimate against measurement, compound 4: 1.1-fold (0.03 log units) above; low and high end bracket the measured number.
By their numbers in this assay, from the lowest: compound 2; then compounds 1, 4 and 3 (each within the scatter of the next).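

In this assay, 3-methylphenyl in place of 4-methylphenyl on the saturated chain carbon bound to the amide-type nitrogen leaves the reading unchanged (no change at the digits printed from compound 1 to compound 4 (within the scatter)), so these two methyl placements are not told apart here. Compound 4 also stays within the scatter of the 3,5-dimethoxyphenyl analogue (a 1.2-fold lower number from compound 3 to compound 4 (0.07 log units; within the scatter)), so compounds 1, 3 and 4 form one group across these three aryl patterns. The step from the 3-phenylpiperidin-1-yl amide remains beyond the scatter (a 7.7-fold higher number from compound 2 to compound 4 (0.89 log units; beyond the scatter)), and among these compounds only the exchange of the whole amine part separates the readings.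

No measurement shown gives a reason for this flat reading on the aryl ring. Going by these compounds, whether the ring stays as undemanding with a carboxylic acid or an amine in place of the methyl remains open.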